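Tert-butyl for methyl on the ring nitrogen of compound 1

A few compounds are considered here, and "the series" means these few. Any claim that something is new, unique, unknown or untested is made for them only; others in the source may bear on it.

Compound 1 `Cn1c(-c2cccnc2)nc2ccc(F)cc21` has been measured in an assay on V79 cells for inhibition of cytochrome P450 11B2, mitochondrial (Homo sapiens), read by HTRF, with a stated time of 1 h (on this read-out higher numbers stand for weaker inhibition and lower numbers for stronger inhibition), where compound 1 gives 12 nM. Among the measured compounds shown here, the only other measured member of the series is compound 2 `N#Cc1cc2c(cc1F)nc(-c1cccnc1)n2C1CC1`, which in this assay gives 0.6 nM. For the measured compounds named here, compound 1 therefore stands at the higher of the two numbers, and the gap to compound 2 lies beyond the scatter; no single-point step links the two, since compound 2 differs from compound 1 in more than one place.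

The next compound, compound 3 `CC(C)(C)n1c(-c2cccnc2)nc2ccc(F)cc21`, differs from compound 1 by tert-butyl in place of methyl on an aromatic nitrogen. Going by the values given here, no measured pair shows what this change does, so its size cannot be read off anything already known.

With nothing to anchor it, the step is expected to be small, and compound 3 is estimated to come out about even with compound 1, the step of a 1.5-fold higher number from compound 1 to compound 3 (0.18 log units; within the scatter) being expected to lie within the usual scatter or only just outside it. For compound 3 in this assay the estimate is 18 nM, with a range from 5 nM to 70 nM.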

Compound 3, half-maximal inhibitory concentration: > 5000 nM
Compound 3 was reported as a limit; the forecaster's own chance of this, stated with the estimate: 2%; middle value at least 270-fold (2.44 log units) away from the limit.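

Among the compounds shown here, on the aromatic nitrogen of the shared core, tert-butyl in place of methyl gives an at least 410-fold higher number from compound 1 to compound 3 (2.61 log units; beyond the scatter), the first single-place step, and it is large. Until now, nothing showed whether the group on this ring nitrogen mattered; this step shows that inhibition in this assay depends strongly on it, with the 3-pyridyl-bearing core and the fluorine left unchanged. The reading for compound 3 is a limit of the assay and not a number, so the step fixes only a minimum size and the real distance remains unknown: the limit of > 5000 nM in this assay, at which 1 of the 3 values shown sits.

The compounds shown leave open whether inhibition falls away gradually between methyl and tert-butyl or only at tert-butyl, and an ethyl or isopropyl group on the same nitrogen of the core of compound 1 would answer that. Going by these compounds, compound 2 carries a different group on this nitrogen but also differs elsewhere, so it cannot settle the question, and whether a group smaller than methyl, such as the bare ring hydrogen, would do better or worse also stays open.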